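Lengthening the isothiocyanate chain of an amide-linked compound

A few compounds are considered here, and "the series" means these few. Any claim that something is new, unique, unknown or untested is made for them only; others in the source may bear on it.

A set of three compounds sharing one core has been measured in a functional assay on NCI-H1299 cells (Homo sapiens) for inhibition, read by CCK-8 assay, with a stated time of 72 h, tested at 10 uM; a lower number here means a weaker effect, a higher number a stronger effect of the compound at the concentration tested. Compound 1 `CN(C)C(=O)c1cc2cnc(Nc3ccc(S(=O)(=O)NCCCN=C=S)cc3)nc2n1C1CCCC1` gives 72.8%, compound 2 `CN(C)C(=O)c1cc2cnc(Nc3ccc(S(=O)(=O)NCCCCN=C=S)cc3)nc2n1C1CCCC1` gives 72.7%, and compound 3 `CN(C)C(=O)c1cc2cnc(Nc3ccc(C(=O)NCCCCN=C=S)cc3)nc2n1C1CCCC1` gives 74.2%. Compound 3 holds the highest of the three numbers, but its gaps to compound 1 and to compound 2 both lie within the scatter, so the three compounds read alike.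

Compound 4 `CN(C)C(=O)c1cc2cnc(Nc3ccc(C(=O)NCCCCCCCN=C=S)cc3)nc2n1C1CCCC1` is the next step from compound 3. The change is a group of 6 heavy atoms (4 carbon, 1 nitrogen, 1 sulfur; no ring) in place of a group of 3 heavy atoms (1 carbon, 1 nitrogen, 1 sulfur; no ring), on a saturated chain carbon, four bonds along the chain from an amide-type nitrogen: a longer saturated chain carries the isothiocyanate end, while the amide link and the rest of the molecule stay as in compound 3.

Among the measured compounds shown here, the step that bears on this is the one from compound 1 to compound 2, which also lengthened the chain before the isothiocyanate, there on the sulfonamide side, and gave a number 0.1 percentage points lower from compound 1 to compound 2 (within the scatter). The step from compound 1 to compound 3, which swapped the sulfonamide for the amide link, gave a number 1.4 percentage points higher from compound 1 to compound 3 (within the scatter). Neither change moved the read-out beyond the scatter, so no step beyond the scatter is expected here either; the expected step from compound 3 to compound 4 in this assay is a number 1.2 percentage points lower from compound 3 to compound 4 (within the scatter).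

Compound 4 is therefore estimated at 73%, expected to fall between 62% and 84%.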

Compound 4, a percentage reported as inhibition, at one concentration (the size of the read-out at that concentration, not a potency): 107%
Compound 4: middle estimate off by 34 percentage points, on the low side, and the stated range ends below it.
By their numbers in this assay, from the lowest: compounds 2, 1 and 3 (each within the scatter of the next); then compound 4.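

In this assay, the saturated chain carrying the isothiocyanate end proves to be a place where the read-out can move a long way: a number 32.8 percentage points higher from compound 3 to compound 4 (beyond the scatter) for a group of 6 heavy atoms in place of a group of 3 heavy atoms, with the amide link unchanged. The earlier lengthening on the sulfonamide side gave no sign of this, with a number 0.1 percentage points lower from compound 1 to compound 2 (within the scatter), so a small extension of the chain there did not predict what a larger one does on the amide side. No measurement shown accounts for the rise.

The compounds shown leave open how the read-out follows chain length on the amide side, since only two lengths appear there, and a longer chain or one of intermediate length could show whether it keeps rising, levels off or falls. They also leave open whether the same long chain on the sulfonamide link gives a similar rise, and whether the isothiocyanate end matters at that length, which an amine in its place could test.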